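The compounds below may be only part of what the source reports. "The series", "measured", "known", "first", "only" and "open" are said of these compounds alone.

Two analogues of the shared core have been measured in a functional assay on DU-145 cells (Homo sapiens) for antiproliferative activity, read by WST assay, with a stated time of 3 days; a higher number here means a weaker inhibitor, a lower number a stronger inhibitor. Compound 1 `CCN(CC)CCCCOc1c(-c2cc(OC)c(OC)c(OC)c2)oc2ccccc2c1=O` gives 13300 nM in this assay. Compound 2 `CCCCN(CCCC)CCCCOc1c(-c2cc(OC)c(OC)c(OC)c2)oc2ccccc2c1=O` gives 15300 nM in this assay. Among the compounds with values here, the single step between them, a 1.2-fold higher number from compound 1 to compound 2 (0.06 log units; within the scatter), leaves the two numbers within the scatter of each other, so compound 2 cannot be set apart from compound 1 on what is known.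

Compound 3 `CCCCCN(CCCCC)CCCCCOc1c(-c2cc(OC)c(OC)c(OC)c2)oc2ccccc2c1=O` is not yet measured. It differs from compound 2 as follows: (dipentylamino)methyl in place of dibutylamino on a saturated chain carbon, four bonds along the chain from an oxygen on an aromatic ring. Within the data shown here, the only step that bears on it is the one from compound 1 to compound 2, which was within the scatter; the change here is larger, but nothing measured points one way or the other. No step beyond the scatter is therefore expected in this assay, and compound 3 is estimated at 16000 nM, with a range of 6000 nM to 45000 nM. This implies an expected step of a 1.0-fold higher number from compound 2 to compound 3 (0.02 log units; within the scatter).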

Compound 3, half-maximal inhibitory concentration: 11700 nM
Compound 3: middle estimate off by 1.4-fold (0.14 log units), on the high side, and the stated range covers the measured number.
By their numbers in this assay, from the lowest: compounds 3, 1 and 2 (each within the scatter of the next).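

In this assay the larger replacement, (dipentylamino)methyl in place of dibutylamino on a saturated chain carbon, four bonds along the chain from an oxygen on an aromatic ring, still gives a step within the scatter (a 1.3-fold lower number from compound 2 to compound 3 (0.12 log units; within the scatter)). The comparison with the diethylamino compound reads the same (a 1.1-fold lower number from compound 1 to compound 3 (0.06 log units; within the scatter)), so diethylamino, dibutylamino and (dipentylamino)methyl cannot be told apart at this position in this assay, even with the largest of the three groups in place. Nothing at hand offers an explanation for this flat result.

Open, as far as these compounds go, is whether a ring amine such as piperidine or morpholine, or a carboxylic acid, in place of these amino groups would give a step beyond the scatter. Also open, from the compounds shown here alone, is what a much shorter chain would do.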